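A few compounds are considered here, and "the series" means these few. Any claim that something is new, unique, unknown or untested is made for them only; others in the source may bear on it.

Measured so far:
Compound 1 `COC(=O)CCNC(=O)[C@@H]1CC=C(CCC=C(C)C)C[C@H]1c1ccccc1`: in an assay on isolated protein for inhibition of Apoptosis regulator Bcl-2 (Homo sapiens), read by fluorescence polarization, with stated times of 5 min and 10 min (a higher number here means a weaker inhibitor, a lower number a stronger inhibitor), compound 1 gives > 23000 nM, which is a limit of the assay and not a number.
Compound 2 `CC(C)=CCCC1=CC[C@@H](C(=O)Nc2ccc(C(=O)O)cc2)[C@H](c2ccccc2)C1`: in this assay compound 2 gives 2200 nM.
Compound 3 `COC(=O)CCNC(=O)[C@H]1CC=C(CCC=C(C)C)C[C@@H]1c1ccccc1`: in this assay compound 3 gives 3100 nM.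

Compound 3 stands at the higher of the two numbers shown, with compound 2 within the scatter of it; compound 1 contributes only a limit. Going by the values given here, compound 1 and compound 3 are mirror images, and the step of an at least 7.4-fold lower number from compound 1 to compound 3 (0.87 log units; beyond the scatter) shows that the configuration drawn for compound 3 is the one that yields a number; the size of that step is open-ended because of the limit of > 23000 nM in this assay, at which 1 of the 3 values shown sits.

Compound 4 `COc1ccc(NC(=O)[C@H]2CC=C(CCC=C(C)C)C[C@@H]2c2ccccc2)cc1` carries 4-methoxyphenyl in place of 2-(methoxycarbonyl)ethyl on an amide-type nitrogen. Among the compounds with values here, the one measured step that bears on this is an at least 10-fold lower number from compound 1 to compound 2 (1.01 log units; beyond the scatter), the same exchange of the amide substituent for a substituted phenyl group, though made in the mirror-image series and with 4-carboxyphenyl rather than 4-methoxyphenyl; that step too is open-ended because of the limit of > 23000 nM in this assay, at which 1 of the 3 values shown sits. It points towards a lower number. Compound 4 is therefore expected to give a modest step downwards, a 2.1-fold lower number from compound 3 to compound 4 (0.32 log units; beyond the scatter), not securely beyond the scatter. Compound 4 is estimated at 1500 nM, with a range from 400 nM to 6000 nM.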

Compound 4, inhibition constant: > 23000 nM
Compound 4: no number, only a limit; the forecaster's own chance of this, stated with the estimate: 10%; middle value at least 15-fold (1.18 log units) from the limit.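

On the amide-type nitrogen, in the configuration drawn for compound 3, 4-methoxyphenyl does not serve as a replacement for 2-(methoxycarbonyl)ethyl in this assay (an at least 7.4-fold higher number from compound 3 to compound 4 (0.87 log units; beyond the scatter)). From the compounds shown here alone, compound 4 gives > 23000 nM as a limit of the assay and not a number, and the size of the step stays open-ended because of that limit: (the limit of > 23000 nM in this assay, at which 2 of the 4 values shown sit). The earlier step (an at least 10-fold lower number from compound 1 to compound 2 (1.01 log units; beyond the scatter)) therefore gives no general rule for a substituted phenyl on this nitrogen: it was read in the mirror-image series with 4-carboxyphenyl, and compound 4 goes against any such rule.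

The compounds shown do not separate the contribution of the aromatic ring from that of its methoxy group, and they do not show how 4-carboxyphenyl behaves in the configuration of compound 3. Also open, going by these compounds, is whether an unsubstituted phenyl, a longer chain or a free carboxylic acid in place of the methyl ester of the 2-(methoxycarbonyl)ethyl group would keep a measurable number in this configuration.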